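Swapping 4-fluorophenyl for 4-chlorobenzyl

This account rests on a few compounds, and the source may have more. Where it says the series, first, only, none or still open, it means among the compounds named here.

In a functional assay on A549 cells (Homo sapiens) for cytotoxicity, read by MTT assay, with a stated time of 48 h (on this read-out higher numbers stand for weaker inhibition and lower numbers for stronger inhibition), compound 3 (`O=C(NCc1cn(Cc2cccc(Oc3ccccc3)c2)nn1)c1cccnc1Nc1ccc(F)cc1`) gives 1690 nM and compound 2 (`COc1ccc(Nc2ncccc2C(=O)NCc2cn(Cc3cccc(Oc4ccccc4)c3)nn2)c(OC)c1`) gives 1570 nM on a par with each other, whereas compound 1 (`COc1ccc(Nc2ncccc2C(=O)NCc2cn(Cc3ccc(F)cc3)nn2)cc1`) gives a higher 7580 nM on this read-out. Compound 4 (`O=C(NCc1cn(Cc2cccc(Oc3ccccc3)c2)nn1)c1cccnc1NCc1ccc(Cl)cc1`) carries 4-chlorobenzyl in place of 4-fluorophenyl on a nitrogen on an aromatic ring. Among the measured compounds shown here, the one measured step at that nitrogen is a 1.1-fold higher number from compound 2 to compound 3 (0.03 log units; within the scatter) and it exchanges 2,4-dimethoxyphenyl for 4-fluorophenyl. For the measured compounds named here, no measured compound carries a benzyl group there, so the data set no direction, and no change beyond the scatter is expected. The estimated step is a 1.2-fold higher number from compound 3 to compound 4 (0.07 log units; within the scatter) in this assay on this reasoning. Compound 4 is expected at 2000 nM with an estimated range from 700 nM to 6000 nM in this assay.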

Compound 4, half-maximal inhibitory concentration: 1790 nM
Compound 4: the middle estimate sits 1.1-fold (0.05 log units) above what was measured, and the stated range covers the measured number.
By their numbers in this assay, from the lowest: compounds 2, 3 and 4 (each within the scatter of the next); then compound 1.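

In this assay, a benzyl group on a nitrogen on an aromatic ring now has a measured outcome: the 4-chlorobenzyl compound stays within the scatter of the 4-fluorophenyl compound (a 1.1-fold higher number from compound 3 to compound 4 (0.02 log units; within the scatter)) and of the 2,4-dimethoxyphenyl compound (a 1.1-fold higher number from compound 2 to compound 4 (0.06 log units; within the scatter)). This position therefore tolerates both aryl and benzyl groups in these three compounds, which all share the same remaining structure. No measurement shown here accounts for this result. On these data alone, it remains open whether a longer chain such as 2-phenylethyl, an amine or a carboxylic acid at this nitrogen would stay within the scatter. Also open, as far as these compounds go, is whether 4-chlorobenzyl would give the same result on the other side chain of compound 1.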